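Moving the chloro on the sulfonyl aryl ring

A few compounds are considered here, and "the series" means these few. Any claim that something is new, unique, unknown or untested is made for them only; others in the source may bear on it.

Compound 1, `O=S(=O)(Nc1ccc(-c2nc3ccccc3o2)cc1)c1ccc(F)c(C(F)(F)F)c1`, gives 82000 nM in an ADME assay on HEK293 cells (Homo sapiens) for cytotoxicity, read by resazurin assay, with a stated time of 48 h; a higher number here means that more compound is tolerated, a lower number that less compound is tolerated.
Compound 2, `O=S(=O)(Nc1ccc2oc(-c3ccccc3)nc2c1)c1ccccc1C(F)(F)F`, gives 80000 nM in this assay.
Compound 3, `O=S(=O)(Nc1ccc2oc(-c3ccccc3)nc2c1)c1ccccc1Cl`, gives 73000 nM in this assay.

Compound 3 stands within the scatter of both other measured compounds: its nearest neighbour is compound 2 and its furthest is compound 1, and neither gap exceeds the usual scatter. The only single-point step measured among these three is a 1.1-fold lower number from compound 2 to compound 3 (0.04 log units; within the scatter), which is within the scatter.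

Compound 4, `O=S(=O)(Nc1ccc2oc(-c3ccccc3)nc2c1)c1cccc(Cl)c1`, is not yet measured. It differs from compound 3 in one place: 3-chlorophenyl in place of 2-chlorophenyl on a sulfonyl sulfur.

Among the measured compounds shown here, no measured step moves the chloro around the ring on the sulfonyl sulfur, so nothing directly bears on this change. For the measured compounds named here, the one comparison available, the step from compound 2 to compound 3, shows that the identity of the group on that ring did not matter beyond the scatter, and the three measured numbers all lie close together. On that basis compound 4 is expected to show no step beyond the scatter, an estimated 1.0-fold higher number from compound 3 to compound 4 (0.01 log units; within the scatter). Compound 4 is therefore estimated at 75000 nM, with an expected range from 35000 nM to 150000 nM.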

Compound 4, half-maximal cytotoxic concentration: 70000 nM
Compound 4: middle estimate off by 1.1-fold (0.03 log units), on the high side; the measured number falls inside the stated range.
By their numbers in this assay, from the lowest: compounds 4, 3, 2 and 1 (each within the scatter of the next).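

Exchanging 2-chlorophenyl for 3-chlorophenyl on a sulfonyl sulfur gives, in this assay, a 1.0-fold lower number from compound 3 to compound 4 (0.02 log units; within the scatter) as its result. The earlier step from trifluoromethyl to chloro changed the group itself, whereas compounds 3 and 4 have the same atoms, joined differently, so this pair shows that this rearrangement also stays within the scatter. Nothing available explains this result.

All of the compounds shown are within the scatter of their neighbours by number, so they do not reveal any change at this position that would move the number beyond the scatter. Going by these compounds, whether an amine or a carboxylic acid in place of the chloro, or a longer chain on the sulfonamide nitrogen, would do so remains open.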